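A few compounds are considered here, and "the series" means these few. Any claim that something is new, unique, unknown or untested is made for them only; others in the source may bear on it.

In an ADME assay on Vero cells (Chlorocebus sabaeus) for cytotoxicity, read by MTT assay, with a stated time of 72 h (a higher number here means that more compound is tolerated, a lower number that less compound is tolerated), the three measured compounds stand as follows:

- compound 1 `COc1ccc(/C=C/C(=O)Nc2nnc(-c3ccccc3)[nH]2)cc1OC`: 1210000 nM
- compound 2 `O=C(/C=C/c1cccc(Cl)c1)Nc1nnc(-c2ccccc2)[nH]1`: 1470000 nM
- compound 3 `O=C(/C=C/c1ccc(Cl)cc1)Nc1nnc(-c2ccccc2)[nH]1`: 1620000 nM

Compound 3 has the highest of the three numbers in this assay, but its nearest neighbour, compound 2, differs by a gap that lies within the scatter, and the furthest, compound 1, also lies within the scatter of it; the three compounds therefore cannot be ordered against one another on these numbers.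

The next compound, compound 4 `COc1ccc(/C=C/C(=O)Nc2nnc(-c3ccccc3)[nH]2)cc1`, follows from compound 3 by a single change: methoxy in place of chloro on an aromatic carbon. Among the measured compounds shown here, only one measured step touches the same part of the molecule, a 1.1-fold higher number from compound 2 to compound 3 (0.04 log units; within the scatter), where the chloro group moved around the ring without a change beyond the scatter. Compound 1, which carries two methoxy groups on the same ring, gives a number in this assay that is also within the scatter of compound 3. For the measured compounds named here, there is thus no measured step that shows an exchange of chloro for methoxy at this position moving the number beyond the scatter, and none in this assay that moves at all beyond the scatter.

Compound 4 is therefore expected to stay close to compound 3, with an estimated step of a 1.2-fold lower number from compound 3 to compound 4 (0.06 log units; within the scatter). The estimate for compound 4 in this assay is 1400000 nM, with a range from 900000 nM to 2200000 nM.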

Compound 4, half-maximal cytotoxic concentration: 1280000 nM
Beside the measured number, compound 4's estimate is 1.1-fold (0.04 log units) above it; low and high end bracket the measured number.
By their numbers in this assay, from the lowest: compounds 1, 4, 2 and 3 (each within the scatter of the next).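

In this assay the exchange of chloro for methoxy on the aromatic carbon para to a large group now has a direct measurement (a 1.3-fold lower number from compound 3 to compound 4 (0.10 log units; within the scatter)), so replacing this one heavy atom with two, and adding one hydrogen-bond acceptor, does not move the number beyond the scatter. The comparison with the 3-chlorophenyl compound gives the same reading (a 1.1-fold lower number from compound 2 to compound 4 (0.06 log units; within the scatter)), and so does the loss of one methoxy group from the ring (a 1.1-fold higher number from compound 1 to compound 4 (0.02 log units; within the scatter)), which shows that this group can also go without a change that can be told from the scatter. No measurement at hand offers an explanation for these small steps.

Going by these compounds, all four compounds keep the shared core and the chain and carry only chloro or methoxy groups on the ring, so it remains open whether an amine or a carboxylic acid at this position would move the number beyond the scatter. Nor do these compounds show what a hydroxyl group or a longer alkoxy chain in place of the methoxy would do, or what a change to the shared core itself would do.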